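A few compounds are considered here, and "the series" means these few. Any claim that something is new, unique, unknown or untested is made for them only; others in the source may bear on it.

Compound 1 `O=C(O)c1cc(-c2cncs2)ccc1O` and compound 2 `O=C(O)c1cc(-c2csnn2)ccc1O` share one core and differ only in the five-membered heteroaryl group attached to it. In a functional assay on the whole organism for inhibition, with Rattus norvegicus as the target, read by paw edema (on this read-out higher numbers stand for an effect only at larger amounts of compound and lower numbers for an effect already at smaller amounts), compound 1 reaches only the limit of the assay, > 200 mg/kg. In this assay compound 2 likewise stops at the limit, > 200 mg/kg. The step that the two limits leave unreadable from compound 1 to compound 2 therefore cannot be read: both values sit at the limit of > 200 mg/kg in this assay, at which 2 of the 2 values shown sit. Compound 3 `O=C(O)c1cc(-c2nccs2)ccc1O` is the next member of the series; its change from compound 2 is 1,3-thiazol-2-yl in place of 1,2,3-thiadiazol-4-yl on an aromatic carbon. Within the data shown here, no measured step bears on this change with a readable size, and the single step known, a step that the two limits leave unreadable from compound 1 to compound 2, shows nothing but two limits. Compound 3 is therefore expected to remain near the limit as well, and the step that the limit leaves unreadable from compound 2 to compound 3 is estimated to stay within the usual scatter rather than beyond it. For compound 3 in this assay the estimate is 250 mg/kg, with a range from 100 mg/kg to 600 mg/kg.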

Compound 3, dose for half-maximal effect: > 250 mg/kg
Compound 3 ended at the assay's limit; the forecaster's own chance of this, stated with the estimate: 80%; the middle value sits exactly at the limit.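

In this assay compound 3 gives > 250 mg/kg, which is a limit and not a number. Among these compounds, no step among compound 1, compound 2 and compound 3 can be read. The compounds shown leave open how these three five-membered heteroaryl groups compare.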